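From oxan-4-yl to 1-methylpyrrolidin-3-yl: an expected fall

The source may report more compounds than this note shows. Statements on the series, on what has been measured and on what is new or still open speak of the compounds shown alone.

Within the data shown here, in a physicochemical assay for lipophilicity, read by HPLC, using the shake flask method, measured as octanol-water partition, at pH 7.4 (on this read-out higher numbers stand for higher lipophilicity and lower numbers for lower lipophilicity), compound 2 `Cc1cc2ncccc2cc1Nc1ncc2c(n1)n(C1CCOCC1)c(=O)n2C` gives 2.5, the highest of the three numbers measured so far. Compound 3 `Cc1cc2nnccc2cc1Nc1ncc2c(n1)n(C1CCN(C)CC1)c(=O)n2C` gives 1.2 and compound 1 `Cc1cc2ncnn2cc1Nc1ncc2c(n1)n(C1CCN(C)CC1)c(=O)n2C` gives 0.3, and both lie below compound 2 by more than the usual scatter.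

The next compound to be measured is compound 4 `Cc1cc2ncccc2cc1Nc1ncc2c(n1)n([C@@H]1CCN(C)C1)c(=O)n2C`, which differs from compound 2 in one place: 1-methylpyrrolidin-3-yl in place of oxan-4-yl on an aromatic nitrogen. Put simply, 1-methylpyrrolidin-3-yl stands in place of oxan-4-yl on an aromatic nitrogen, and the entering group has one defined stereocentre.

Among the measured compounds shown here, no two measured compounds differ in only one place, so no measured step shows directly what this exchange does. The available guide is indirect. Compound 3 at 1.2 and compound 1 at 0.3 also carry a ring containing a methylated nitrogen on that aromatic nitrogen, and both read lower than compound 2. However, they also differ from compound 2 elsewhere, so the comparison is loose.

A fall beyond the scatter is therefore expected, with an estimated step of a number 0.90 log units lower from compound 2 to compound 4 (beyond the scatter). In this assay, the estimated value for compound 4 is 1.6, with an expected range of 1.1 to 2.1.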

Compound 4, distribution coefficient: 1.2
Estimate against measurement, compound 4: 0.40 log units above; measured number inside the range.
By their numbers in this assay, from the lowest: compound 1; then compounds 3 and 4 (each within the scatter of the next); then compound 2.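

In this assay, the exchange of oxan-4-yl for 1-methylpyrrolidin-3-yl on an aromatic nitrogen gives a number 1.30 log units lower from compound 2 to compound 4 (beyond the scatter) and is the first change shown at this position with the rest of the molecule held constant. The step is large even though both groups have 6 heavy atoms, 0 hydrogen-bond donors and 1 hydrogen-bond acceptor, so these counts alone do not tell the two groups apart at this position. Nothing measured here explains the fall, and the exchange alters the ring size, the hetero atom and the presence of a defined stereocentre all at once.

It remains open which of these differences accounts for the step, and an oxolan-3-yl group, a five-membered ring holding oxygen, on the core of compound 2 would separate ring size from the change of hetero atom. Also open, on these data alone, are how the opposite arrangement at the stereocentre of 1-methylpyrrolidin-3-yl would read and whether a step of this size would recur on the cores of compound 1 and compound 3.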